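Trading heptyl for tert-butoxycarbonyl on a side chain

This account rests on a few compounds, and the source may have more. Where it says the series, first, only, none or still open, it means among the compounds named here.

Compound 1 `Cc1[nH]c2ccccc2c(=O)c1Br` – > 20000 nM
Compound 2 `CCCCCCC/C=C/c1c(C)[nH]c2ccccc2c1=O` – < 2000 nM

Among the measured compounds shown here, only two readings are available so far. In a physicochemical assay for solubility, read by HPLC, at pH 7.4 (on this read-out higher numbers stand for higher solubility and lower numbers for lower solubility), compound 1 gives > 20000 nM as its reading, and this is a limit of the assay, not a number. Compound 2 stands at < 2000 nM in this assay, and this too is only a limit, so no exact figure exists for compound 2 yet.

The next compound to be measured is compound 3 `Cc1[nH]c2ccccc2c(=O)c1/C=C/C(=O)OC(C)(C)C`, which differs from compound 2 in one place (tert-butoxycarbonyl in place of heptyl on a double-bonded chain carbon bound to a double-bonded chain carbon). The group that enters carries hydrogen-bond acceptors, and the heptyl that leaves carries none.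

For the measured compounds named here, no two measured compounds differ in just one place, so no measured step can guide the size of this change. The expected step (an at least 3.5-fold higher number from compound 2 to compound 3 (0.54 log units; beyond the scatter)) in this assay points upward, beyond the usual scatter, though this is a judgement and not a measured trend. A reading that is again only a limit would be no surprise. The estimated value for compound 3 is 7000 nM in this assay (expected range 2500 nM to 20000 nM).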

Compound 3, solubility: > 20000 nM
Compound 3 gave a limit, no number; the forecaster's own chance of this, stated with the estimate: 40%; at least 2.8-fold (0.45 log units) between middle value and limit.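

With compound 3 there is now a measured step at this place, on a double-bonded chain carbon bound to a double-bonded chain carbon: in this assay, putting tert-butoxycarbonyl in place of heptyl gives an at least 10-fold higher number from compound 2 to compound 3 (1.00 log units; beyond the scatter). The size of this step is a minimum, and by the count of atoms the exchange is an even one, since heptyl and tert-butoxycarbonyl each have 7 heavy atoms, while the entering group has 2 hydrogen-bond acceptors and the leaving group has 0. The reading for compound 3 is only a limit, and it is the same limit that compound 1 gave, so these two compounds cannot be ranked against each other: the limit of > 20000 nM in this assay, at which 2 of the 3 values shown sit.

On these data alone, the true distance between compound 2 and compound 3 stays unknown because neither compound has an exact reading, and compound 2 gives a limit on the other side: the limit of < 2000 nM in this assay, at which 1 of the 3 values shown sits. It also remains open whether a carboxylic acid, an amine or a shorter chain at this same place would give an exact number in this assay, and so show which part of the tert-butoxycarbonyl group goes with the step.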